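From Carbonyl to Benzyl on the Aromatic Nitrogen

The compounds below may be only part of what the source reports. "The series", "measured", "known", "first", "only" and "open" are said of these compounds alone.

Of the compounds shown here, three sharing one core have been tested in an ADME assay on BV-2 cells (Mus musculus) for cytotoxicity, read by MTT assay, with a stated time of 48 h, tested at 5 uM; a lower number here means a stronger effect, a higher number a weaker effect of the compound at the concentration tested. Compound 1 `O=C1COCCN1c1ccc(/N=C\c2c[nH]c3ccccc23)cc1` gives 101%. Compound 2 `Cc1ccc(S(=O)(=O)n2cc(/C=N\c3ccc(N4CCOCC4=O)cc3)c3ccccc32)cc1` gives 89.1%. Compound 3 `O=C1COCCN1c1ccc(/N=C\c2cn(C(=O)c3ccc(Cl)cc3)c3ccccc23)cc1` gives 93.7%, a number that sits within the scatter of both others: a number 7.3 percentage points lower from compound 1 to compound 3 (within the scatter) and a number 4.6 percentage points higher from compound 2 to compound 3 (within the scatter). Only a number 11.9 percentage points lower from compound 1 to compound 2 (beyond the scatter) reaches beyond the scatter. Compound 4 `O=C1COCCN1c1ccc(/N=C\c2cn(Cc3ccc(F)cc3)c3ccccc23)cc1` carries a further change at the same place: 4-fluorobenzyl in place of (4-chlorophenyl)carbonyl on an aromatic nitrogen. For the measured compounds named here, the two steps that touch this nitrogen and end at compound 3, a number 7.3 percentage points lower from compound 1 to compound 3 (within the scatter) and a number 4.6 percentage points higher from compound 2 to compound 3 (within the scatter), stayed within the scatter, and no step of the kind now made has been measured. Compound 4 is therefore expected to show no step beyond the scatter, a number 1.7 percentage points lower from compound 3 to compound 4 (within the scatter). For compound 4 the estimated value in this assay is 92%, with a range from 80% to 104%.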

Compound 4, a percentage reported as activity, at one concentration (the size of the read-out at that concentration, not a potency): 69.3%
Compound 4: the middle estimate sits 22.7 percentage points above what was measured; the whole stated range lies above it.
By their numbers in this assay, from the lowest: compound 4; then compounds 2, 3 and 1 (each within the scatter of the next, the first and the last beyond it).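

At this aromatic nitrogen, this assay does respond to the group carried: a number 24.4 percentage points lower from compound 3 to compound 4 (beyond the scatter), a number 19.8 percentage points lower from compound 2 to compound 4 (beyond the scatter) and a number 31.7 percentage points lower from compound 1 to compound 4 (beyond the scatter). For the compounds shown here, with all three steps beyond the scatter, 4-fluorobenzyl sets compound 4 apart from hydrogen, (4-methylphenyl)sulfonyl and (4-chlorophenyl)carbonyl alike, which the earlier compounds, with only one step beyond the scatter among them, did not show. Nothing available explains this difference. The compounds shown leave open whether the fluorine matters, since a plain benzyl or 4-chlorobenzyl would separate it from the benzyl link itself. They also leave open how a longer chain ending in an amine would read at this nitrogen.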